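The compounds below may be only part of what the source reports. "The series", "measured", "known", "first", "only" and "open" are said of these compounds alone.

Measured so far in a functional assay on A549 cells (Homo sapiens) for antiproliferative activity, read by MTT assay, with a stated time of 72 h; a higher number here means a weaker inhibitor, a lower number a stronger inhibitor:
- compound 1 `NC1=NC2(CCOCC2)N(OCCCOc2ccc(Cl)cc2Cl)C(N)=N1`: 70 nM
- compound 2 `NC1=NC2(CCOCC2)N(OCCCOc2cc(Cl)c(Cl)cc2Cl)C(N)=N1`: 680 nM
- compound 3 `NC1=NC2(CCOCC2)N(OCCCOc2ccccc2Br)C(N)=N1`: 160 nM

All three share one core and differ only in the halogenated phenyl group at the end of the chain. Compound 3, at 160 nM, sits in the middle of this small set. Its nearest neighbour is compound 1, and the gap is a 2.3-fold higher number from compound 1 to compound 3 (0.36 log units; beyond the scatter). Compound 2 lies further off, with a 4.3-fold lower number from compound 2 to compound 3 (0.63 log units; beyond the scatter).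

The next compound is compound 4 `NC1=NC2(CCOCC2)N(OCCCOc2cccc(Cl)c2)C(N)=N1`, which has 3-chlorophenyl in place of 2-bromophenyl on an oxygen on a saturated carbon.

Going by the values given here, no measured pair tests this exact swap, so the evidence is indirect. The two steps just given also exchange the whole phenyl group, and both are modest. The largest step in the set, a 9.7-fold higher number from compound 1 to compound 2 (0.99 log units; beyond the scatter), comes from adding a chloro, and compound 4 gains no extra halogen over compound 3. The data give no direction for the change, so a large step seems unlikely, though a modest one either way remains possible.

In this assay, the expected result is no real change beyond the scatter, with an estimated 1.1-fold lower number from compound 3 to compound 4 (0.03 log units; within the scatter). For compound 4 the estimate is 150 nM, with an expected range of 55 nM to 420 nM.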

Compound 4, half-maximal inhibitory concentration: 150 nM
Beside the measured number, compound 4's estimate shows no gap at the digits printed; the measured number falls inside the stated range.
By their numbers in this assay, from the lowest: compound 1; then compounds 4 and 3 (each within the scatter of the next); then compound 2.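

In this assay, the step to the 3-chlorophenyl group gives a 1.1-fold lower number from compound 3 to compound 4 (0.03 log units; within the scatter), so at this place on the oxygen, the 3-chlorophenyl and 2-bromophenyl groups cannot be told apart, even though the halogen and its ring position change together. Compound 4 also adds to the halogen series: the step to it from the 2,4-dichlorophenyl group gives a 2.1-fold higher number from compound 1 to compound 4 (0.33 log units; beyond the scatter), while the step to it from the 2,4,5-trichlorophenyl group gives a 4.5-fold lower number from compound 2 to compound 4 (0.66 log units; beyond the scatter), so the number of chlorines does not set the order in one direction, since the dichloro compound 1 has a lower number than the monochloro compound 4 and the trichloro compound 2 has a higher one. No measurement shown here accounts for these differences.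

Halogen and ring position changed in one step. The match between compound 3 and compound 4 could reflect two effects that cancel or two changes that each do little, and a 3-bromophenyl or 2-chlorophenyl group would separate them. From the compounds shown here alone, it also remains open how a plain phenyl group, a methoxy-bearing phenyl group or a longer chain would behave at this place.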